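This account rests on a few compounds, and the source may have more. Where it says the series, first, only, none or still open, it means among the compounds named here.

Values in a functional assay on K562/Adr cells (Homo sapiens) for cytotoxicity, read by sulforhodamine B assay, with a stated time of 48 h; a lower number here means a stronger inhibitor, a higher number a weaker inhibitor
- Compound 1 `CCN(CC)CCCn1c(=O)/c(=C/c2cc(OC)c(OC)c(OC)c2)s/c1=C1/C(=O)Nc2ccc(C)cc21` gives 2020 nM
- Compound 2 `CCN(CC)CCCn1c(=O)/c(=C/c2ccccc2O)s/c1=C1\C(=O)Nc2ccc(C)cc21` gives 30600 nM
- Compound 3 `CCN(CC)CCCn1c(=O)/c(=C/c2ccc(O)cc2)s/c1=C1\C(=O)Nc2ccc(Cl)cc21` gives 48800 nM

Compound 3 (48800 nM) lies within the scatter of compound 2 and beyond the scatter from compound 1, whose number is lower. Compound 4 (`CCN(CC)CCCn1c(=O)/c(=C/c2ccc(O)cc2)s/c1=C1/C(=O)Nc2ccc(Cl)cc21`) has the same atoms and bonds as compound 3 and differs only in configuration as drawn (the two compounds have the same atoms and bonds and differ only in configuration as drawn: 1 of 2 stereo elements differ; a double bond is drawn Z in compound 3 and E in compound 4). Within the data shown here, no measured pair isolates this kind of change, so its size in this assay is unknown. No step beyond the scatter is expected, and the range stays wide on the low side since compound 1 (2020 nM) shows that lower numbers occur in this series. The estimated change is a 1.6-fold lower number from compound 3 to compound 4 (0.21 log units; within the scatter) and is expected to stay within the scatter. The estimated value for compound 4 is 30000 nM (expected range from 9000 nM to 70000 nM).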

Compound 4, half-maximal inhibitory concentration: 48800 nM
Estimate against measurement, compound 4: 1.6-fold (0.21 log units) below; measured number inside the range.
By their numbers in this assay, from the lowest: compound 1; then compounds 2, 3 and 4 (each within the scatter of the next).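

Among these compounds, the pair gives the first direct reading of a configuration change, which no earlier comparison isolated: the fact that compounds 3 and 4 differ only in the configuration as drawn. In this assay this double bond going from Z to E gives no change at the digits printed from compound 3 to compound 4 (within the scatter), so with these substituents the drawn configuration leaves the number unmoved.

Still open, from the compounds shown here alone, is whether the same holds with other substituents, such as a carboxylic acid in place of the hydroxy group. The compounds shown also leave open whether the chloro group matters to this outcome, since no pair here has the two configurations with a different group there.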